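Trimming the Chain End of a Catechol Vinyl Sulfone

The source may hold more compounds than are shown below. What is called first, only, known or untested is meant among the compounds shown, and "the series" means these compounds.

Compound 1 `C=CCCCCCS(=O)(=O)/C=C/c1ccc(O)c(O)c1` carries an unsaturated chain on the sulfonyl group of the shared core. For the measured compounds named here, in a functional assay, read by fluorescence and spectrophotometry, with a stated time of 1 h (a lower number here means that less compound is needed, a higher number that more compound is needed for the effect), compound 1 gives 7100 nM, the highest of the two numbers measured so far. Going by the values given here, its only neighbour, compound 2 `C=CCCCCCCS(=O)(=O)/C=C/c1ccc(O)c(O)c1`, gives 6400 nM in this assay. The step of a 1.1-fold lower number from compound 1 to compound 2 (0.05 log units; within the scatter) shows that putting allyl in place of vinyl at that chain carbon leaves the read-out essentially where it was.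

Compound 3 `CCCCCS(=O)(=O)/C=C/c1ccc(O)c(O)c1` goes the other way: it differs from compound 1 by hydrogen in place of vinyl on a saturated chain carbon, five bonds along the chain from a sulfonyl sulfur. The chain is thus cut short and ends in a hydrogen. Among the compounds with values here, only the step from compound 1 to compound 2 speaks to this position, and it was within the scatter, so the far end of the chain appears tolerant of change. That step added atoms rather than removing them, so the direction for a shorter chain is uncertain. Compound 3 is therefore expected to come out close to compound 1, with a step of a 1.1-fold higher number from compound 1 to compound 3 (0.05 log units; within the scatter), and its estimate in this assay is 8000 nM, within a range of 4000 nM to 16000 nM.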

Compound 3, half-maximal effective concentration: 8100 nM
Compound 3: middle estimate off by 1.0-fold (0.01 log units), on the low side; the range from low to high includes it.
By their numbers in this assay, from the lowest: compounds 2, 1 and 3 (each within the scatter of the next).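

Hydrogen in place of vinyl on this saturated chain carbon, five bonds along the chain from the sulfonyl sulfur, gives (a 1.1-fold higher number from compound 1 to compound 3 (0.06 log units; within the scatter)) in this assay, and hydrogen in place of allyl at the same carbon gives (a 1.3-fold higher number from compound 2 to compound 3 (0.10 log units; within the scatter)). For the compounds shown here, the only earlier step lengthened the chain and kept its double bond, so these two steps add something new: the chain can also be shortened, and the double bond outside the aromatic ring can be lost, with no change beyond the scatter. Among these three compounds, then, the unsaturated chain end is not needed for the read-out, and the three numbers cannot be put in any meaningful order.

On these data alone, all three chains contain only carbon and hydrogen, so it remains open whether this tolerance would hold for an amine, a carboxylic acid or a hydroxyl group at the chain end. A phenyl ring there, or a much longer chain, is equally open, since the steps shown span only a narrow range of chain length. Nothing available here accounts for why the read-out stays so steady across these changes.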